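A few compounds are considered here, and "the series" means these few. Any claim that something is new, unique, unknown or untested is made for them only; others in the source may bear on it.

Compound 1 `COc1c(OC)c(OC(C)=O)c2ccccc2c1OC(C)=O` gives 2.39 in a physicochemical assay for lipophilicity; on this read-out higher numbers stand for higher lipophilicity and lower numbers for lower lipophilicity. Compound 3 `COc1c(OC)c(OC(C)=O)c2c(C)cccc2c1OC(C)=O` differs from compound 1 by methyl in place of hydrogen on an aromatic carbon and in this assay compound 3 gives 2.8, so that a number 0.41 log units higher from compound 1 to compound 3 (beyond the scatter). Compound 2 `COc1c(OC)c(OC(=O)C(C)C)c2ccccc2c1OC(=O)C(C)C` stands apart: in this assay compound 2 gives 4.61, the highest of the three numbers, and the difference between its core and the core of compound 1 is not broken down here. Compound 4 `COc1c(OC)c(OC(=O)C(C)C)c2c(C)cccc2c1OC(=O)C(C)C`, not yet measured, differs from compound 2 by methyl in place of hydrogen on an aromatic carbon, the same change as that from compound 1 to compound 3. The step of a number 0.39 log units higher from compound 2 to compound 4 (beyond the scatter) is expected to match the earlier one because a number 0.41 log units higher from compound 1 to compound 3 (beyond the scatter) was seen on the other core. Compound 4 is therefore estimated at 5, with a range from 4.6 to 5.4.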

Compound 4, partition coefficient: 5
For compound 4 middle estimate and measured number coincide at the digits printed; low and high end bracket the measured number.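

In this assay, methyl in place of hydrogen on an aromatic carbon gives a number 0.39 log units higher from compound 2 to compound 4 (beyond the scatter) and, on the core of compound 1, a number 0.41 log units higher from compound 1 to compound 3 (beyond the scatter), so the change carried across both cores shown with a step of similar size. Among the compounds shown here, this is only one pair of cores, which differ at their ester groups, and it does not show that the step would hold on any other core. Nothing here explains why the step repeats.

The compounds shown leave open whether an ethyl chain or chlorine in place of the methyl would behave alike. They also leave open whether the methyl step would persist if an amine or a carboxylic acid replaced the ester groups.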